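Moving the fluorine around the fluorophenyl ring

The compounds below may be only part of what the source reports. "The series", "measured", "known", "first", "only" and "open" are said of these compounds alone.

Measured compounds:
- compound 1 `Cc1nc(-c2ccccc2F)c(C(=O)N2CCN(c3cccc(Cl)c3)CC2)o1`: 39.4 nM
- compound 2 `Cc1ccc(C)c(N2CCN(C(=O)c3oc(C)nc3-c3ccc(F)cc3)CC2)c1`: 358 nM
- compound 3 `Cc1ccc(C)c(N2CCN(C(=O)c3oc(C)nc3-c3cccc(F)c3)CC2)c1`: 204 nM

In a functional assay on HL-60 cells (Homo sapiens) for inhibition, read by MTT assay, with a stated time of 72 h (on this read-out higher numbers stand for weaker inhibition and lower numbers for stronger inhibition), compound 3 gives 204 nM, the second highest of the three numbers. Its nearest neighbour is compound 2, whose value lies within the scatter of it; the furthest is compound 1, whose lower number lies beyond the scatter. Compound 1 differs from compound 3 in two places, so its two values are all that can be said of that pair.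

Compound 4 `Cc1ccc(C)c(N2CCN(C(=O)c3oc(C)nc3-c3ccccc3F)CC2)c1` is not yet measured. It differs from compound 3 as follows: 2-fluorophenyl in place of 3-fluorophenyl on an aromatic carbon.

Going by the values given here, the only step that bears on this change is a 1.8-fold lower number from compound 2 to compound 3 (0.24 log units; within the scatter). Shifting the fluorine from one position of the ring to another thus gave no movement beyond the scatter. The same kind of shift is involved here, so for compound 4 a step of about a 1.4-fold lower number from compound 3 to compound 4 (0.13 log units; within the scatter) is expected in this assay, i.e. nothing clearly beyond the scatter. Compound 4 is therefore estimated at 150 nM, with a range from 55 nM to 420 nM.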

Compound 4, half-maximal inhibitory concentration: 319 nM
Beside the measured number, compound 4's estimate is 2.1-fold (0.33 log units) below it; the range from low to high includes it.
By their numbers in this assay, from the lowest: compound 1; then compounds 3, 4 and 2 (each within the scatter of the next).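

In this assay the series shows a 1.6-fold higher number from compound 3 to compound 4 (0.19 log units; within the scatter) and a 1.1-fold lower number from compound 2 to compound 4 (0.05 log units; within the scatter), so 2-fluorophenyl, 3-fluorophenyl and 4-fluorophenyl all lie within the scatter of one another on the core carrying 2,5-dimethylphenyl. Going by these compounds alone, the same measurement gives the first single-change link to compound 1, with an 8.1-fold higher number from compound 1 to compound 4 (0.91 log units; beyond the scatter) for 2,5-dimethylphenyl in place of 3-chlorophenyl on the amine nitrogen in a ring, and among the steps read so far only this change on that nitrogen goes beyond the scatter. Nothing available accounts for either the flat fluorine walk or the larger step on the nitrogen.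

Still open, on these data alone, is whether 3-chlorophenyl on that nitrogen gives a similar step with 3-fluorophenyl or 4-fluorophenyl in place of 2-fluorophenyl. The compounds shown also leave open whether a methoxy group or a nitrile on the phenyl ring would move the number beyond the scatter.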